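The source may hold more compounds than are shown below. What is called first, only, known or untested is meant among the compounds shown, and "the series" means these compounds.

Values in a physicochemical assay for lipophilicity; on this read-out higher numbers stand for higher lipophilicity and lower numbers for lower lipophilicity:
- compound 1 `CN1CCN(c2cc(C(F)(F)F)ccc2[C@H]2CCOc3cc(S(=O)(=O)Nc4nccs4)ccc32)CC1`: 2.1
- compound 2 `Cn1nccc1-c1cc(C(F)(F)F)ccc1[C@H]1CCOc2cc(S(=O)(=O)Nc3nccs3)ccc21`: 2.2

Compound 2, at 2.2, sits within the scatter of compound 1. Compound 3 `Cn1nccc1-c1cc(C(F)(F)F)ccc1[C@H]1CCOc2cc(S(=O)(=O)Nc3ncccn3)ccc21` changes the group on the sulfonamide nitrogen: pyrimidin-2-yl in place of 1,3-thiazol-2-yl on a sulfonamide nitrogen. Among the compounds with values here, the only measured step, a number 0.10 log units higher from compound 1 to compound 2 (within the scatter), concerns a group on an aromatic carbon, so it offers no direct guide. No change on the sulfonamide nitrogen has been measured, which keeps the expectation loose. A modest fall in this assay is expected, estimated as a number 0.40 log units lower from compound 2 to compound 3 (beyond the scatter). The estimate for compound 3 is 1.8, with an expected range of 1.3 to 2.3.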

Compound 3, distribution coefficient: 3.7
The estimate for compound 3 lay 1.90 log units below the measured number, outside the stated range (above it).
By their numbers in this assay, from the lowest: compounds 1 and 2 (each within the scatter of the next); then compound 3.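

In this assay, pyrimidin-2-yl in place of 1,3-thiazol-2-yl on a sulfonamide nitrogen gives a number 1.50 log units higher from compound 2 to compound 3 (beyond the scatter). Within the data shown here, the sulfonamide nitrogen is thus a position where a change of one aromatic ring for another can move this read-out strongly, whereas the only earlier step, on an aromatic carbon, was a number 0.10 log units higher from compound 1 to compound 2 (within the scatter). No measurement at hand accounts for the rise.

Open, from the compounds shown here alone, is whether the rise carries over when 4-methylpiperazin-1-yl stands on the aromatic carbon. Also open, going by these compounds, is how pyridin-2-yl or 1,3,4-thiadiazol-2-yl on the sulfonamide nitrogen would read in this assay.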